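Swapping the amine aryl group on a spirocyclic amide core

The source may report more compounds than this note shows. Statements on the series, on what has been measured and on what is new or still open speak of the compounds shown alone.

Measured compounds in a functional assay on HEK293 cells for antagonist activity at Orexin receptor type 2 (Homo sapiens), read by FLIPR and calcium flux; a lower number here means a less potent compound, a higher number a more potent compound, by a factor of ten per unit of this negative logarithm:
compound 1 `O=C(c1cc(Cl)ccc1-c1ncccn1)N1CC2(CC2)C[C@H]1CNc1cc(C(F)(F)F)ccn1`: 7.1
compound 2 `O=C(c1nc(C(F)(F)F)ccc1-c1ncccn1)N1CC2(CC2)C[C@H]1CNc1ccc(C(F)(F)F)cn1`: 5
compound 3 `Cc1nc(C(=O)N2CC3(CC3)C[C@H]2CNc2ncc(Cl)cn2)c(-c2ccccc2)s1`: 6.8

Of the compounds shown here, three sharing a spirocyclic amide core have been measured in this assay, and compound 3 stands second of the three numbers. Its value lies close to that of compound 1, the gap between them being within the usual scatter, so no order between these two can be read. Against compound 2, compound 3 stands clearly higher, by a gap well beyond the scatter; since compound 2 also carries a different aryl group on its amide, this gap cannot be tied to any single change.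

Compound 4 `Cc1nc(C(=O)N2CC3(CC3)C[C@H]2CNc2ccc(C(F)(F)F)cn2)c(-c2ccccc2)s1` is not yet measured. It keeps the core of compound 3 and differs only at the amine: 5-(trifluoromethyl)pyridin-2-yl in place of 5-chloropyrimidin-2-yl on an amine nitrogen. Going by the values given here, no pair of measured compounds shows this exact exchange on this core, so the step can only be guessed. In this assay the step from compound 3 to compound 4 is expected to be small, a number 0.10 log units lower from compound 3 to compound 4 (within the scatter), not clearly beyond the scatter in either direction. Compound 4 is therefore estimated at 6.7, within a range from 6 to 7.4.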

Compound 4, negative logarithm of the antagonist equilibrium constant: 7.7
For compound 4 the middle estimate is 1.00 log units below the measured one; measured number outside the range, above it.
By their numbers in this assay, from the lowest: compound 2; then compounds 3 and 1 (each within the scatter of the next); then compound 4.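

In this assay, the exchange of 5-chloropyrimidin-2-yl for 5-(trifluoromethyl)pyridin-2-yl on the amine nitrogen gives a number 0.90 log units higher from compound 3 to compound 4 (beyond the scatter), the first step read in this set between compounds that differ in one place, and it shows that the aryl group on this amine can move the number beyond the scatter while the rest of the molecule stays fixed. The entering group does not carry a high number by itself, as the same group stands on the amine of compound 2 at 5, though the amide part of that compound is different, so the two cannot be set against each other as a single change. Nothing available bears on why the step from the chloropyrimidine to the trifluoromethylpyridine is upward.

As far as these compounds go, the exchange alters the ring hetero atoms and the ring substituent together, so it remains open which of the two carries the step, a question that 5-chloropyridin-2-yl or 5-(trifluoromethyl)pyrimidin-2-yl on the same amine nitrogen would address. From the compounds shown here alone, it is also open whether a methoxy group or a nitrile at this ring substituent would hold the number of compound 4.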